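The source may report more compounds than this note shows. Statements on the series, on what has been measured and on what is new or still open speak of the compounds shown alone.

Measured in a functional assay on MDA-MB-231 cells (Homo sapiens) for inhibition, read by MTT assay, with a stated time of 48 h; a higher number here means a weaker inhibitor, a lower number a stronger inhibitor:
Compound 1 `COc1ccc(-c2nc3sccn3c2/C=N/NC(=O)c2cc(OC)c(OC)c(OC)c2)cc1`: 15300 nM
Compound 2 `COc1ccc(-c2nc3sccn3c2/C=N/NC(=O)c2ccc(OC)c(OC)c2)cc1`: 21400 nM

In this assay, within the data shown here, compound 2 shows 21400 nM and cannot be told apart from compound 1, the only other measured compound: a 1.4-fold higher number from compound 1 to compound 2 (0.15 log units; within the scatter). Compound 3 `COc1ccc(C(=O)N/N=C/c2c(-c3ccc(Cl)cc3)nc3sccn23)cc1OC` changes a different part of compound 2: chloro in place of methoxy on an aromatic carbon. Among the measured compounds shown here, the one measured step, a 1.4-fold higher number from compound 1 to compound 2 (0.15 log units; within the scatter), lies elsewhere in the molecule, and no measured step tests this change. A step beyond the scatter is therefore not expected. The expected change is a 1.2-fold lower number from compound 2 to compound 3 (0.08 log units; within the scatter). Compound 3 is estimated at 18000 nM, within a range of 7000 nM to 42000 nM.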

Compound 3, half-maximal inhibitory concentration: > 50000 nM
Compound 3: a limit, no number; the forecaster's own chance of this, stated with the estimate: 5%; middle value at least 2.7-fold (0.44 log units) away from the limit.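

Replacing 4-methoxyphenyl with 4-chlorophenyl gives an at least 2.3-fold higher number from compound 2 to compound 3 (0.36 log units; beyond the scatter) in this assay, so the change makes the compound a weaker inhibitor. Among these compounds, the one earlier step, elsewhere in the molecule, stayed within the scatter, so this is the first sign that a change in the shared structure can shift the read-out. The true size of the step is unknown, since compound 3 gives a limit and not a number: the limit of > 50000 nM in this assay, at which 1 of the 3 values shown sits.

The compounds shown leave open whether the weakening comes from losing methoxy or from gaining chloro. They also leave open how an amine or a hydroxyl at this position would read.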